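The source may report more compounds than this note shows. Statements on the series, on what has been measured and on what is new or still open speak of the compounds shown alone.

Measured in a functional assay on A549 cells (Homo sapiens) for antiproliferative activity, with a stated time of 72 h; a higher number here means a weaker inhibitor, a lower number a stronger inhibitor:
- compound 1 `C/C(=C\c1csc(C)n1)[C@@H]1C[C@@H]2OC(c3ccccc3)=N[C@H]2CCC[C@H](C)[C@H](O)[C@@H](C)C(=O)C(C)(C)[C@@H](O)CC(=O)O1`: 16.4 nM
- compound 2 `C/C(=C\c1csc(C)n1)[C@@H]1C[C@@H]2OC(c3ccc(C)cc3)=N[C@H]2CCC[C@H](C)[C@H](O)[C@@H](C)C(=O)C(C)(C)[C@@H](O)CC(=O)O1`: 2.9 nM
- compound 3 `CCc1ccc(C2=N[C@H]3CCC[C@H](C)[C@H](O)[C@@H](C)C(=O)C(C)(C)[C@@H](O)CC(=O)O[C@H](/C(C)=C/c4csc(C)n4)C[C@@H]3O2)cc1`: 379 nM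

Compound 3 has the highest number of the three, and its steps to both others lie beyond the scatter, so it is the weakest inhibitor so far. Compound 4 `C/C(=C\c1csc(C)n1)[C@@H]1C[C@@H]2OC(c3ccc(C(C)C)cc3)=N[C@H]2CCC[C@H](C)[C@H](O)[C@@H](C)C(=O)C(C)(C)[C@@H](O)CC(=O)O1` replaces its 4-ethylphenyl with 4-isopropylphenyl: methyl in place of hydrogen on a saturated chain carbon bound to an aromatic carbon and a saturated chain carbon.

For the measured compounds named here, the closest precedent is the same kind of change, methyl in place of hydrogen, made on compound 2: a 130-fold higher number from compound 2 to compound 3 (2.12 log units; beyond the scatter), a large rise. The other steps do not run in one direction. a 5.7-fold lower number from compound 1 to compound 2 (0.75 log units; beyond the scatter) is a modest fall, while a 23-fold higher number from compound 1 to compound 3 (1.36 log units; beyond the scatter) is a large rise. Three compounds cannot show whether the rise continues, so a modest upward step in this assay is expected, possibly none beyond the scatter, with a wide margin on either side. The expected step is a 1.6-fold higher number from compound 3 to compound 4 (0.20 log units; within the scatter). For compound 4 the estimated value is 600 nM, with an expected range of 100 nM to 3000 nM.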

Compound 4, half-maximal inhibitory concentration: 4870 nM
For compound 4 the middle estimate is 8.1-fold (0.91 log units) below the measured one; measured number above the stated range.
By their numbers in this assay, from the lowest: compound 2; then compound 1; then compound 3; then compound 4.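

In this assay, adding methyl on the saturated chain carbon bound to an aromatic carbon again raises the number (a 13-fold higher number from compound 3 to compound 4 (1.11 log units; beyond the scatter)), so the rise from the 4-methylphenyl to the 4-ethylphenyl continues with 4-isopropylphenyl, and compound 4 is the weakest inhibitor of the four. For the compounds shown here, the gaps to the smaller groups are the widest (a 1700-fold higher number from compound 2 to compound 4 (3.23 log units; beyond the scatter); a 300-fold higher number from compound 1 to compound 4 (2.47 log units; beyond the scatter)), and only the step from hydrogen to methyl goes against this rise with each added carbon. No measured evidence available here accounts for these steps.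

Going by these compounds, it remains open whether the rise follows carbon count or branching, which a straight propyl chain would help to separate. Also open, on these data alone, is how a methoxy group or an amine at this aromatic carbon would compare with methyl.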